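Triazole substituent change and expected HepG2 antiproliferative activity

A few compounds are considered here, and "the series" means these few. Any claim that something is new, unique, unknown or untested is made for them only; others in the source may bear on it.

Measured compounds:
compound 1, `CCCCCc1ccc(-c2cn(C[C@H](O)[C@H]3OC(=O)C(OCc4ccccc4)=C3OCc3ccccc3)nn2)cc1`, 7460 nM
compound 2, `O=C1O[C@H]([C@@H](O)Cn2cc(CCCCl)nn2)C(OCc2ccccc2)=C1OCc1ccccc1`, 35000 nM

In a functional assay on HepG2 cells (Homo sapiens) for antiproliferative activity, read by MTT assay, with a stated time of 72 h (on this read-out higher numbers stand for weaker inhibition and lower numbers for stronger inhibition), compound 1 gives 7460 nM, and compound 2 gives 35000 nM. Compound 2 thus stands at the higher of the two numbers, the step of a 4.7-fold higher number from compound 1 to compound 2 (0.67 log units; beyond the scatter) setting it apart from compound 1.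

Compound 3, `COc1ccc(-c2cn(C[C@H](O)[C@H]3OC(=O)C(OCc4ccccc4)=C3OCc3ccccc3)nn2)cc1`, has not yet been measured in this assay. It differs from compound 2 by 4-methoxyphenyl in place of 3-chloropropyl on an aromatic carbon. Within the data shown here, the only step that bears on this change is a 4.7-fold higher number from compound 1 to compound 2 (0.67 log units; beyond the scatter), which went from one ring-bearing substituent to the 3-chloropropyl group and raised the number by a modest amount. Reversing toward a ring-bearing group is therefore expected to lower the number, though the methoxy group has no measured precedent here, so the size is uncertain.

Compound 3 is expected to give about 12000 nM in this assay, within 4000 nM to 40000 nM, a step of a 2.9-fold lower number from compound 2 to compound 3 (0.46 log units; beyond the scatter).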

Compound 3, half-maximal inhibitory concentration: 46400 nM
The estimate for compound 3 lay 3.9-fold (0.59 log units) below the measured number, and the stated range ends below it.
By their numbers in this assay, from the lowest: compound 1; then compounds 2 and 3 (each within the scatter of the next).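

In this assay, placing 4-methoxyphenyl instead of 3-chloropropyl on this aromatic carbon gives a 1.3-fold higher number from compound 2 to compound 3 (0.12 log units; within the scatter), so the presence of a six-membered aromatic ring here does not by itself separate the two compounds. The substituent carried by that ring does make a difference in this pair, as methoxy in place of pentyl gives a 6.2-fold higher number from compound 1 to compound 3 (0.79 log units; beyond the scatter) and places the advantage of compound 1 with its 4-pentylphenyl group rather than with the ring alone. No measured evidence is available to explain either step.

The compounds shown leave open whether a longer or shorter alkyl chain on that ring, such as butyl or octyl, would shift the number further. They also leave open how an amine or a carboxylic acid in that place would read out.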